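Methoxy to Dimethylamino: Expected Effect on Growth Inhibition

The source may hold more compounds than are shown below. What is called first, only, known or untested is meant among the compounds shown, and "the series" means these compounds.

Compound 1 `COc1ncnc2c1c(-c1cccs1)cn2[C@@H]1O[C@H](CO)[C@@H](O)[C@H]1O`: 6200 nM
Compound 2 `COc1nc(N)nc2c1c(-c1cccs1)cn2[C@@H]1O[C@H](CO)[C@@H](O)[C@H]1O`: > 20000 nM, which is a limit of the assay and not a number.

Among the measured compounds shown here, compound 1 is the only compound that gives a definite number in a functional assay on K562 cells (Homo sapiens), read by MTT assay, with a stated time of 72 h; on this read-out higher numbers stand for weaker inhibition and lower numbers for stronger inhibition; the other value shown is a limit. For the measured compounds named here, the single measured step is an at least 3.2-fold higher number from compound 1 to compound 2 (0.50 log units; beyond the scatter), with amino in place of hydrogen on an aromatic carbon, and it ends at the limit of > 20000 nM in this assay, at which 1 of the 2 values shown sits, so its true size is not known beyond being at least modest.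

Compound 3 `CN(C)c1ncnc2c1c(-c1cccs1)cn2[C@@H]1O[C@H](CO)[C@@H](O)[C@H]1O` differs from compound 1 by dimethylamino in place of methoxy on an aromatic carbon. This change is not the same as the measured one: it swaps one small neutral group for another of similar size at a different place, rather than adding a group where hydrogen was. The measured step therefore bears on it only weakly, and no move beyond the scatter is clearly called for.

Compound 3 is estimated at 8000 nM, within 2500 nM to 25000 nM, which means an expected step of a 1.3-fold higher number from compound 1 to compound 3 (0.11 log units; within the scatter).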

Compound 3, half-maximal inhibitory concentration: > 20000 nM
Compound 3 ended at the assay's limit; the forecaster's own chance of this, stated with the estimate: 30%; middle value at least 2.5-fold (0.39 log units) away from the limit.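

Putting dimethylamino in place of methoxy on this aromatic carbon gives an at least 3.2-fold higher number from compound 1 to compound 3 (0.50 log units; beyond the scatter) in this assay, so the earlier finding on the amino group of compound 2, which sits at a different place, now has a counterpart at this position, where a swap of one small group for another is not neutral. Compound 3 reads > 20000 nM, which is a limit of the assay and not a number. Compound 1 therefore remains the only compound with a definite number, and the true size of the step stays unknown: the limit of > 20000 nM in this assay, at which 2 of the 3 values shown sit.

The compounds shown do not separate the two parts of this change, the nitrogen that enters in place of oxygen and the larger group that it carries, so either could lie behind the loss of growth inhibition. A smaller amine such as methylamino, or a longer chain such as ethoxy, at the same position would help to tell these apart and show whether any group other than methoxy keeps a measurable number here.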